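Removing the trifluoromethyl group: an expectation for compound 4

A few compounds are considered here, and "the series" means these few. Any claim that something is new, unique, unknown or untested is made for them only; others in the source may bear on it.

Compound 1 `COCC(C(=O)N1CCN(c2cccc(C(F)(F)F)c2)CC1)N1C(=O)CCC1=O` gives 75% in a functional assay on the whole organism (strain Swiss) with Mus musculus as the target, in the maximal electroshock model, with a stated time of 0.5 h, at a dose of 100 mg/kg by the intraperitoneal route; on this read-out higher numbers stand for a stronger effect at the one dose given and lower numbers for a weaker effect.
Compound 2 `CCC(C(=O)N1CCN(c2cccc(C(F)(F)F)c2)CC1)N1C(=O)CCC1=O` gives 50% in this assay.
Compound 3 `CC(C(=O)N1CCN(c2cccc(C(F)(F)F)c2)CC1)N1C(=O)CCC1=O` gives 75% in this assay.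

Compound 2 stands lowest of the three numbers: the change is a number 25 percentage points lower from compound 1 to compound 2 (beyond the scatter) and a number 25 percentage points higher from compound 2 to compound 3 (beyond the scatter), both beyond the scatter. Compound 4 `CCC(C(=O)N1CCN(c2ccccc2)CC1)N1C(=O)CCC1=O` differs from compound 2 in one place: hydrogen in place of trifluoromethyl on an aromatic carbon. Within the data shown here, every measured step here alters the saturated chain carbon two bonds along the chain from an amide-type nitrogen in a ring and a carbonyl carbon; none alters the aromatic ring, so no measured step bears on this change. With nothing to point either way, no step beyond the scatter is expected. Compound 4 is estimated at 50% in this assay, between 25% and 75%, which means an expected step of no change at the digits printed from compound 2 to compound 4 (within the scatter).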

Compound 4, a percentage reported as activity, at one dose (the size of the read-out at that dose, not a potency): 25%
Compound 4: middle estimate off by 25 percentage points, on the high side; low and high end bracket the measured number.
By their numbers in this assay, from the lowest: compound 4; then compound 2; then compounds 1 and 3 (each within the scatter of the next).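

Hydrogen in place of trifluoromethyl on an aromatic carbon gives a number 25 percentage points lower from compound 2 to compound 4 (beyond the scatter) in this assay, so the aromatic ring, untouched by the earlier steps, also affects this read-out. In this single pair, the compound carrying trifluoromethyl shows the stronger effect at the one dose given. Nothing available explains this step.

On these data alone, whether a chlorine atom or a nitrile on this aromatic carbon would keep the read-out of compound 2 remains open. So does whether removing trifluoromethyl would have a similar effect with the chain of compound 1 or compound 3.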